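Moving the double bond within the indene of compound 2

A few compounds are considered here, and "the series" means these few. Any claim that something is new, unique, unknown or untested is made for them only; others in the source may bear on it.

Compound 1 `c1ccc2c(c1)CCC2CCN1CCN(c2cccc3c2OCCO3)CC1`: 4.01 mg/kg
Compound 2 `C1=C(CCN2CCN(c3cccc4c3OCCO4)CC2)c2ccccc2C1`: 0.3 mg/kg

In an assay for activation of Adrenergic receptor alpha-1 (Rattus norvegicus) (on this read-out higher numbers stand for an effect only at larger amounts of compound and lower numbers for an effect already at smaller amounts), compound 2 gives 0.3 mg/kg, the lowest of the two numbers; compound 1 gives 4.01 mg/kg, and the step of a 13-fold lower number from compound 1 to compound 2 (1.13 log units; beyond the scatter) is large. Compound 3 `C1=C(CCN2CCN(c3cccc4c3OCCO4)CC2)Cc2ccccc21` differs from compound 2 by a group of 9 heavy atoms (9 carbon; one five-membered non-aromatic ring of carbon only, one six-membered aromatic ring of carbon only) in place of a group of 9 heavy atoms (9 carbon; one five-membered non-aromatic ring of carbon only, one six-membered aromatic ring of carbon only), on a saturated chain carbon, two bonds along the chain from an amine nitrogen in a ring. Among the compounds with values here, no measured step covers this rearrangement; the only measured step, a 13-fold lower number from compound 1 to compound 2 (1.13 log units; beyond the scatter), concerns a different pair. The change a 2.0-fold higher number from compound 2 to compound 3 (0.30 log units; within the scatter) is therefore expected to stay modest. Compound 3 is estimated at 0.6 mg/kg, within 0.2 mg/kg to 2 mg/kg.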

Compound 3, dose for half-maximal effect: 0.17 mg/kg
Compound 3: the middle estimate sits 3.5-fold (0.55 log units) above what was measured; the measured number lies below the stated range.
By their numbers in this assay, from the lowest: compounds 3 and 2 (each within the scatter of the next); then compound 1.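

In this position the place of the double bond within the group made no readable difference in this assay (a 1.8-fold lower number from compound 2 to compound 3 (0.25 log units; within the scatter)). The large gain over compound 1 held for both unsaturated groups, and compound 3 repeated it (a 24-fold lower number from compound 1 to compound 3 (1.37 log units; beyond the scatter)). Nothing available bears on why these results arise. The compounds shown leave open whether a longer chain to the amine nitrogen in a ring would hold the number at this level. They also leave open what a hydroxyl group on the five-membered non-aromatic ring would do.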